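The source may report more compounds than this note shows. Statements on the series, on what has been measured and on what is new or still open speak of the compounds shown alone.

Measured in an ADME assay on HeLa cells (Homo sapiens) for cytotoxicity; a higher number here means that more compound is tolerated, a lower number that less compound is tolerated:
- compound 1 `CC(=O)OC[C@H]1O[C@@H](n2cc(-c3cc(-c4ccc(C(C)(C)C)cc4)no3)c(=O)[nH]c2=O)C[C@@H]1OC(C)=O`: 3000 nM
- compound 2 `CC(=O)OC[C@H]1O[C@@H](n2cc(-c3cc(-c4ccccc4)no3)c(=O)[nH]c2=O)C[C@@H]1OC(C)=O`: 3000 nM
- compound 3 `CCc1ccc(-c2cc(-c3cn([C@H]4C[C@H](OC(C)=O)[C@@H](COC(C)=O)O4)c(=O)[nH]c3=O)on2)cc1`: 3000 nM

Level with compound 1 and compound 2 at the digits shown, compound 3 stands at 3000 nM. The next analogue is compound 4 `CC(=O)OC[C@H]1O[C@@H](n2cc(-c3cc(-c4ccc(C(C)C)cc4)no3)c(=O)[nH]c2=O)C[C@@H]1OC(C)=O`. It differs from compound 3 by one change: methyl in place of hydrogen on a saturated chain carbon bound to an aromatic carbon and a saturated chain carbon. In other words, ethyl becomes isopropyl, and 4-ethylphenyl becomes 4-isopropylphenyl.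

All three measured steps concern this same group. They are no change at the digits printed from compound 1 to compound 2 (within the scatter), no change at the digits printed from compound 1 to compound 3 (within the scatter) and no change at the digits printed from compound 2 to compound 3 (within the scatter). Hydrogen, ethyl and tert-butyl thus give the same reading, and none of these steps offers a direction to carry forward. Compound 4 has not been measured with isopropyl in this place, so the expectation rests on these three compounds alone. No shift beyond the scatter is expected in this assay.

The expected change is no change at the digits printed from compound 3 to compound 4 (within the scatter).

The estimated value for compound 4 is 3000 nM, with an expected range of 1500 nM to 6000 nM.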

Compound 4, half-maximal cytotoxic concentration: 3000 nM
The estimate for compound 4 equals the measured number at the digits printed, within the range that was stated.
By their numbers in this assay, from the lowest: compounds 1, 2, 3 and 4 (each within the scatter of the next).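

In this assay, methyl in place of hydrogen on a saturated chain carbon bound to an aromatic carbon and a saturated chain carbon shows no change at the digits printed from compound 3 to compound 4 (within the scatter) and adds the isopropyl reading to the series. The comparison with hydrogen shows no change at the digits printed from compound 2 to compound 4 (within the scatter) and the comparison with tert-butyl shows no change at the digits printed from compound 1 to compound 4 (within the scatter), so hydrogen, ethyl, isopropyl and tert-butyl on this aromatic carbon all read alike across compounds 1 to 4, with none going against this. Nothing available explains this flat reading.

On these data alone, whether an amine, a carboxylic acid or a longer chain such as octyl in this place would depart from compound 4 at 3000 nM stays open. Also open, as far as these compounds go, is how free hydroxyl groups in place of the acetate esters on the shared core would read.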